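The source may report more compounds than this note shows. Statements on the series, on what has been measured and on what is new or still open speak of the compounds shown alone.

Measured so far, in a functional assay on C6 cells (Rattus norvegicus) for cytotoxicity, read by MTT assay, with a stated time of 24 h; on this read-out higher numbers stand for weaker inhibition and lower numbers for stronger inhibition:
Compound 1 `Cn1nnnc1SCC(=O)N/N=c1/scc(-c2ccccc2)n1-c1ccccc1`: 67.7 ug/mL
Compound 2 `O=C(CSc1nnnn1-c1ccccc1)N/N=c1/scc(-c2ccccc2)n1-c1ccccc1`: 8.3 ug/mL
Compound 3 `O=C(CSc1ncccn1)N/N=c1/scc(-c2ccccc2)n1-c1ccccc1`: "not determined" (no result reported)

Among the compounds with values here, compound 2 gives the lowest number of the two reported in this assay; the one step measured, an 8.2-fold lower number from compound 1 to compound 2 (0.91 log units; beyond the scatter), is phenyl in place of methyl on an aromatic nitrogen. Compound 3 has no value in this assay.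

Compound 4 `O=C(CSc1nnnn1-c1ccccc1)N/N=c1/scc(-c2ccc(Br)cc2)n1-c1ccccc1` differs from compound 2 by bromo in place of hydrogen on an aromatic carbon. Within the data shown here, no measured step involves a change on this phenyl, so nothing bears directly on it; the only known step concerns the other end of the shared core. With no guidance either way, the number for compound 4 is expected to stay within the scatter of compound 2, that is no change at the digits printed from compound 2 to compound 4 (within the scatter). Compound 4 is therefore estimated at 8.3 ug/mL, within 3 ug/mL to 23 ug/mL.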

Compound 4, half-maximal inhibitory concentration: 21 ug/mL
Compound 4: the middle estimate sits 2.5-fold (0.40 log units) below what was measured, within the range that was stated.
By their numbers in this assay, from the lowest: compound 2; then compound 4; then compound 1.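

In this assay the ring that takes the bromo proves sensitive to substitution: phenyl to 4-bromophenyl gives a 2.5-fold higher number from compound 2 to compound 4 (0.40 log units; beyond the scatter) and so moves toward weaker inhibition. Within the data shown here, this is the first reading at this position, and its direction is opposite to that of the step at the aromatic nitrogen, an 8.2-fold lower number from compound 1 to compound 2 (0.91 log units; beyond the scatter) in the same assay. Nothing available accounts for the bromo step. From the compounds shown here alone, whether an amine or a methoxy group at this place shifts the number the same way stays open. So does whether bromo acts alike with methyl on the aromatic nitrogen.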